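Shortening the hydroxyethyl side chain of compound 2

A few compounds are considered here, and "the series" means these few. Any claim that something is new, unique, unknown or untested is made for them only; others in the source may bear on it.

In a functional assay on HL-60 cells (Homo sapiens) for inhibition, read by MTT assay, with a stated time of 72 h, tested at 50 uM (on this read-out lower numbers stand for less inhibition of growth and higher numbers for more inhibition of growth at the one concentration tested), compound 2 (`C=CCc1cc(O)c(O)c(CN2CCC(CCO)CC2)c1`) gives 52.1%, the middle of three numbers: compound 1 (`C=CCc1cc(O)c(O)c(CN2CCC(C)CC2)c1`) gives 91.8% and compound 3 (`C=CCc1ccc(OCc2cn(-c3cccc(C#N)c3)nn2)c(O)c1`) gives 30.9%. Compound 4 (`C=CCc1cc(O)c(O)c(CN2CCC(CO)CC2)c1`) differs from compound 2 as follows: hydroxy in place of hydroxymethyl on a saturated chain carbon bound to a saturated ring carbon. In words, this is hydroxy in place of hydroxymethyl on a saturated chain carbon bound to a saturated ring carbon. Within the data shown here, the one measured step that bears on it is the large a number 39.7 percentage points lower from compound 1 to compound 2 (beyond the scatter), where hydroxymethyl replaced hydrogen at that same place. Undoing part of that addition should recover part of that loss, so a moderate rise is expected. The expected step is a number 12.9 percentage points higher from compound 2 to compound 4 (beyond the scatter). In this assay compound 4 is estimated at 65%, with an expected range of 42% to 88%.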

Compound 4, percent growth inhibition at one concentration: 43.3%
The estimate for compound 4 lay 21.7 percentage points above the measured number; the range from low to high includes it.
By their numbers in this assay, from the lowest: compound 3; then compounds 4 and 2 (each within the scatter of the next); then compound 1.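

At this place on the saturated ring, the length of the hydroxy-bearing chain does not separate the two compounds in this assay: the shortening gives a number 8.8 percentage points lower from compound 2 to compound 4 (within the scatter) and so no real difference. The large drop stays with the shorter chain too, with a number 48.5 percentage points lower from compound 1 to compound 4 (beyond the scatter) for the change that brings in the hydroxy, so among compounds 1, 2 and 4 the low numbers go with a hydroxy-bearing chain of either length. No measurement given here explains this drop. The compounds shown leave open whether an amine, a carboxylic acid or a longer hydroxy-bearing chain at this place would give a number nearer compound 1 or compound 2.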